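Working notes: two measured compounds and one open estimate

The source may report more compounds than this note shows. Statements on the series, on what has been measured and on what is new or still open speak of the compounds shown alone.

compound 1 `C=C1CC[C@H]2C(C)(C)CCC[C@]2(C)[C@H]1C/C=C1\CC(O)OC1=O` — 79%
compound 2 `C=C1CC[C@H]2C(C)(C)CCC[C@]2(C)[C@H]1C/C=C1\C=COC1=O` — 82.6%

In an ADME assay on RAW264.7 cells (Mus musculus) for cytotoxicity, read by luminescence and CellTiter-Glo, with a stated time of 18 h, tested at 20 uM (on this read-out higher numbers stand for a weaker effect at the one concentration tested and lower numbers for a stronger effect), compound 1 gives 79% and compound 2 gives 82.6%, the two numbers lying within the usual scatter of each other, so no order between them is drawn. Compound 3 `C=C1CC[C@H]2C(C)(C)CCC[C@]2(C)[C@H]1CC=O` is not yet measured. Relative to compound 2 it carries a group of 2 heavy atoms (1 carbon, 1 oxygen; no ring) in place of a group of 7 heavy atoms (5 carbon, 2 oxygen; one five-membered non-aromatic ring with 1 hetero atom), on a saturated chain carbon bound to a saturated ring carbon. Going by the values given here, no step between measured compounds is available, and the two measured numbers give no direction. The step is expected to be a number 2.6 percentage points lower from compound 2 to compound 3 (within the scatter), none beyond the scatter. Compound 3 is estimated at 80%, with a range from 60% to 100%.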

Compound 3, a percentage reported as activity, at one concentration (the size of the read-out at that concentration, not a potency): 91.9%
Beside the measured number, compound 3's estimate is 11.9 percentage points below it, and the stated range covers the measured number.
By their numbers in this assay, from the lowest: compounds 1, 2 and 3 (each within the scatter of the next, the first and the last beyond it).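

In this assay, formyl in place of the five-membered non-aromatic ring group, on a saturated chain carbon bound to a saturated ring carbon, gives a number 9.3 percentage points higher from compound 2 to compound 3 (within the scatter). This place therefore tolerates the loss of the whole ring group with no step beyond the scatter, so the ring is not shown to be needed for the read-out at this concentration. No measured evidence accounts for this step. Still open, from the compounds shown here alone, is whether an amine, a carboxylic acid or a longer chain at this place would stay within the scatter of compound 3. The compounds shown also do not separate the formyl from the shortened chain that carries it.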